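Benzyl in place of the carbamate chain: cytotoxicity outlook

This account rests on a few compounds, and the source may have more. Where it says the series, first, only, none or still open, it means among the compounds named here.

Compound 1 `Cc1nc(NC(C)C)nc(N[C@@H]2C[C@H](CO)[C@@H](O)[C@H]2O)c1-c1nc2ccccc2s1` sets the reference point of the series: in an ADME assay on cells (Homo sapiens) for cytotoxicity, read by polymerase chain reaction, with a stated time of 3 days (on this read-out lower numbers stand for higher toxicity in this test and higher numbers for lower toxicity in this test), compound 1 gives 13000 nM. Compound 2 `CCOC(=O)NCCNc1nc(C)c(-c2nc3ccccc3s2)c(N[C@@H]2C[C@H](CO)[C@@H](O)[C@H]2O)n1` carries a longer chain on the same ring nitrogen, and in this assay compound 2 gives 12000 nM. Within the data shown here, the only measured step, a 1.1-fold lower number from compound 1 to compound 2 (0.03 log units; within the scatter), did not move the read-out beyond repeat variation. On the two numbers available, compound 2 and compound 1 cannot be told apart; compound 2 simply stands within the scatter of compound 1.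

Compound 3 `Cc1nc(NCc2ccccc2)nc(N[C@@H]2C[C@H](CO)[C@@H](O)[C@H]2O)c1-c1nc2ccccc2s1` is the next step from compound 2. The structural change is phenyl in place of ((ethoxycarbonyl)amino)methyl on a saturated chain carbon bound to a nitrogen on an aromatic ring. Among the measured compounds shown here, the one step that bears on this position, a 1.1-fold lower number from compound 1 to compound 2 (0.03 log units; within the scatter), exchanged one substituent on that ring nitrogen for another and stayed within the scatter, so no firm direction is indicated for a further exchange at the same place. The expectation for compound 3 is therefore a step of no change at the digits printed from compound 2 to compound 3 (within the scatter), meaning no change beyond the scatter. In this assay compound 3 is estimated at 12000 nM, with a likely range from 5000 nM to 30000 nM.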

Compound 3, half-maximal cytotoxic concentration: 9000 nM
Beside the measured number, compound 3's estimate is 1.3-fold (0.12 log units) above it; the measured number falls inside the stated range.
By their numbers in this assay, from the lowest: compounds 3, 2 and 1 (each within the scatter of the next).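

With benzyl on the ring nitrogen, this position has now carried isopropyl, 2-((ethoxycarbonyl)amino)ethyl and benzyl, and in this assay the two new steps, a 1.3-fold lower number from compound 2 to compound 3 (0.12 log units; within the scatter) and a 1.4-fold lower number from compound 1 to compound 3 (0.16 log units; within the scatter), both stay within the scatter. The new information is that a six-membered aromatic ring of carbon only, with 0 hydrogen-bond donors and 0 hydrogen-bond acceptors, can replace ((ethoxycarbonyl)amino)methyl, with 1 hydrogen-bond donor and 2 hydrogen-bond acceptors, on the saturated chain carbon without a step beyond the scatter, so even this exchange of a ring for an open chain leaves the compounds unresolved. No supporting measurement bears on this result, and the read-out alone offers no explanation for it.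

Still open, on these data alone, is whether any group on this ring nitrogen gives a step beyond the scatter in this assay, for example a primary amine, a carboxylic acid, a longer alkyl chain or a benzyl carrying a fluorine on its ring. Also open, as far as these compounds go, is whether a change elsewhere on the shared core, such as at the hydroxymethyl group, would move the read-out when this nitrogen substituent stays fixed.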